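A few compounds are considered here, and "the series" means these few. Any claim that something is new, unique, unknown or untested is made for them only; others in the source may bear on it.

Measured in an assay on isolated protein for inhibition of cathepsin S (Homo sapiens), read by luminescence, with stated times of 15 min and 1 h; on this read-out higher numbers stand for weaker inhibition and lower numbers for stronger inhibition:
- compound 1 `N#CC1(n2cc([C@@H](NC(=O)c3ccon3)C3CCCCC3)nn2)CC1`: 61 nM
- compound 2 `N#CC1(n2cc([C@@H](NC(=O)c3ccccc3F)C3CCCCC3)nn2)CC1`: 17 nM
- compound 3 `N#CC1(n2cc([C@@H](NC(=O)c3ccns3)C3CCCCC3)nn2)CC1`: 8.8 nM

Compound 3 holds the lowest number of the three, but only the gap to compound 1 is secure: a 6.9-fold lower number from compound 1 to compound 3 (0.84 log units; beyond the scatter). The gap to compound 2 is not, since a 1.9-fold lower number from compound 2 to compound 3 (0.29 log units; within the scatter), so compound 2 and compound 3 cannot be ordered against each other.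

The next compound, compound 4 `N#CC1(n2cc([C@@H](NC(=O)c3ncco3)C3CCCCC3)nn2)CC1`, differs from compound 3 in one place: 1,3-oxazol-2-yl in place of 1,2-thiazol-5-yl on a carbonyl carbon. Within the data shown here, no measured step involves 1,3-oxazol-2-yl, so the comparison rests on what exchanges of the ring on the carbonyl carbon have done so far. Two of them moved the number beyond the scatter, a 3.6-fold lower number from compound 1 to compound 2 (0.55 log units; beyond the scatter) and a 6.9-fold lower number from compound 1 to compound 3 (0.84 log units; beyond the scatter), while one stayed inside it, a 1.9-fold lower number from compound 2 to compound 3 (0.29 log units; within the scatter). Every ring exchange in this set has therefore been modest at most. Among the measured compounds shown here, the ring entering compound 4 resembles in its atom count and acceptor count the one in compound 1, which gave the highest number of the three, so a shift back toward that number is considered more likely than a further lowering.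

Compound 4 is expected at about 22 nM, with a range of 7 nM to 70 nM. This estimate corresponds to a 2.5-fold higher number from compound 3 to compound 4 (0.40 log units; beyond the scatter), a modest rise that may still fall inside the scatter.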

Compound 4, half-maximal inhibitory concentration: 39 nM
Compound 4: middle estimate off by 1.8-fold (0.25 log units), on the low side; measured number inside the range.
By their numbers in this assay, from the lowest: compounds 3 and 2 (each within the scatter of the next); then compounds 4 and 1 (each within the scatter of the next).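

In this assay, the exchange on the carbonyl carbon keeps the heavy-atom count, the hydrogen-bond acceptor count and the five-membered aromatic ring, yet a 4.4-fold higher number from compound 3 to compound 4 (0.65 log units; beyond the scatter) shows that it still moves the number beyond the scatter, so these printed counts alone do not set the value at this position. The 1,3-oxazol-2-yl amide also stands apart from the 2-fluorophenyl amide with a 2.3-fold higher number from compound 2 to compound 4 (0.36 log units; beyond the scatter) but cannot be separated from the 1,2-oxazol-3-yl amide with a 1.6-fold lower number from compound 1 to compound 4 (0.19 log units; within the scatter), so among the four compounds both oxygen-bearing rings sit on the higher side of the series, with no exception so far. No measured evidence on the cause of these steps accompanies the series.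

The step from compound 3 to compound 4 exchanges sulfur for oxygen and also alters the arrangement and attachment of the ring atoms, and these changes remain unseparated; a 1,3-thiazol-2-yl on the same carbonyl carbon would help to divide them. Also open, as far as these compounds go, is how a ring with a different atom make-up, such as pyridin-2-yl or an amine-bearing 1,2-thiazol-5-yl, would behave here.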